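The compounds below may be only part of what the source reports. "The series", "measured", "known", "first", "only" and "open" are said of these compounds alone.

The compounds here fall into two groups by their core. Compound 1 `Cc1nccn1-c1cnc(NCc2c(F)ccc3c2CCO3)c2cn[nH]c(=O)c12` and compound 2 `CNC(=O)c1cc(-c2cnc(NCc3c(F)ccc4c3CCO4)c3cn[nH]c(=O)c23)n(C)n1` share one core, while compound 3 `O=C(Nc1ccccc1)c1cnc(NCc2c(F)ccc3c2CCO3)n2cnnc12` carries another. In a physicochemical assay for solubility, read by LC-MS, in phosphate buffer, with a stated time of 24 h, at pH 7.4 (a higher number here means a more soluble compound, a lower number a less soluble compound), compound 1 gives 7000 nM. In this assay compound 2 gives 7000 nM, and the step of no change at the digits printed from compound 1 to compound 2 (within the scatter) therefore stays within the scatter. In this assay compound 3 gives only a limit, < 1000 nM, not a measured number. That reading is the limit of < 1000 nM in this assay, at which 1 of the 3 values shown sits.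

Compound 4 `CN(c1ccccc1)c1cnc(NCc2c(F)ccc3c2CCO3)n2cnnc12` differs from compound 3 in one place: methyl(phenyl)amino in place of phenylcarbamoyl on an aromatic carbon. Going by the values given here, none of the measured steps bears directly on this change: the only measured step joins two compounds of the other core at a different position, and compound 3 itself stands at a limit rather than at a number. The expectation for compound 4 in this assay therefore rests on compound 3 alone, with no measured guidance on the size or direction of the change.

The step of an at least 1.5-fold higher number from compound 3 to compound 4 (0.17 log units; that floor lies within the scatter) is expected to be small, with a real chance that the assay again reports only a limit. Compound 4 is expected to give about 1500 nM in this assay, within a range from 400 nM to 6000 nM.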

Compound 4, solubility: < 2000 nM
Compound 4: only a limit was reported; the forecaster's own chance of this, stated with the estimate: 50%; the middle value lies beyond the limit too.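

Going by these compounds alone, compound 3 and compound 4 both stand at limits in this assay rather than at measured numbers, so no step between them can be read. The compounds shown leave open how soluble compound 3 and compound 4 actually are, and whether methyl(phenyl)amino in place of phenylcarbamoyl on this core changes the reading at all.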